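A few compounds are considered here, and "the series" means these few. Any claim that something is new, unique, unknown or untested is made for them only; others in the source may bear on it.

Compound 1 `CCNC(=O)NOCc1ccc(/C=C/C(=O)NO)cc1`: 35400 nM
Compound 2 `Cc1cc(C)c(NC(=O)NOCc2ccc(/C=C/C(=O)NO)cc2)c(C)c1`: 3390 nM

Both values come from a functional assay on A2780 cells (Homo sapiens) for antiproliferative activity, read by MTT assay, with a stated time of 72 h; a higher number here means a weaker inhibitor, a lower number a stronger inhibitor. Compound 2 has the lower of the two numbers, which makes it the stronger inhibitor of this pair.

Compound 3 `COc1ccc(NC(=O)NOCc2ccc(/C=C/C(=O)NO)cc2)cc1` keeps the shared core and changes one group, with 4-methoxyphenyl in place of 2,4,6-trimethylphenyl on an amide-type nitrogen. Both groups contain one six-membered aromatic ring of carbon only.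

Within the data shown here, only one measured step bears on this change: a 10-fold lower number from compound 1 to compound 2 (1.02 log units; beyond the scatter). That large step, beyond the scatter, put 2,4,6-trimethylphenyl in place of ethyl at the same nitrogen. No measurement compares two aromatic groups, so the data give no direction for the new change, and no step beyond the scatter is expected. The estimated step is a 1.1-fold lower number from compound 2 to compound 3 (0.05 log units; within the scatter). For compound 3 the estimate is 3000 nM, with an expected range from 1000 nM to 9000 nM.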

Compound 3, half-maximal inhibitory concentration: 1150 nM
Estimate against measurement, compound 3: 2.6-fold (0.42 log units) above, and the stated range covers the measured number.
By their numbers in this assay, from the lowest: compound 3; then compound 2; then compound 1.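

The earlier pair showed only that 2,4,6-trimethylphenyl on this amide-type nitrogen gives a lower number than ethyl. The new result shows that the choice of aromatic group also matters in this assay: putting 4-methoxyphenyl in place of 2,4,6-trimethylphenyl gives a 2.9-fold lower number from compound 2 to compound 3 (0.47 log units; beyond the scatter), and putting it in place of ethyl gives a 31-fold lower number from compound 1 to compound 3 (1.49 log units; beyond the scatter), a larger step than either aromatic comparison alone suggests. Nothing measured here gives a reason for these steps.

The two aromatic groups differ in more than one feature at once, so the compounds shown cannot separate the gain of the methoxy group from the loss of the methyl groups. A plain phenyl group on the same nitrogen would help to tell these two changes apart.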